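Isopropyl in place of hydrogen on compound 3

The source may report more compounds than this note shows. Statements on the series, on what has been measured and on what is new or still open speak of the compounds shown alone.

In a functional assay on PC-3 cells (Homo sapiens) for antiproliferative activity, read by MTT assay, with a stated time of 24 h (a lower number here means a stronger inhibitor, a higher number a weaker inhibitor), compound 1 `CCn1c(C(=O)NCCNC(=O)OC(C)(C)C)ccc1C(CC)(CC)c1ccc(OCS(=O)(=O)c2ccccc2)c(C)c1` reports > 50000 nM as a limit and not a number. Compound 2 `CCn1c(C(=O)N[C@H](CO)CCCO)ccc1C(CC)(CC)c1ccc(OCS(=O)(=O)c2ccccc2)c(C)c1` gives 6810 nM and compound 3 `CCn1c(C(=O)NCC(=O)O)ccc1C(CC)(CC)c1ccc(OCS(=O)(=O)c2ccccc2)c(C)c1` gives 30100 nM which is the higher of these two numbers. For the measured compounds named here, compound 4 `CCn1c(C(=O)N[C@@H](C(=O)O)C(C)C)ccc1C(CC)(CC)c1ccc(OCS(=O)(=O)c2ccccc2)c(C)c1` differs from compound 3 as follows: isopropyl in place of hydrogen on a saturated chain carbon bound to an amide-type nitrogen and a carbonyl carbon and no measured step makes this exact change. The closest steps swap the whole group on the amide-type nitrogen. The step of a 4.4-fold higher number from compound 2 to compound 3 (0.65 log units; beyond the scatter) is modest, while an at least 1.6-fold lower number from compound 1 to compound 3 (0.22 log units; that floor lies within the scatter) has a floor within the scatter, so these larger groups point in no single direction. The expected result is a 1.2-fold lower number from compound 3 to compound 4 (0.08 log units; within the scatter) in this assay and no step beyond the scatter is expected. Compound 4 is estimated at 25000 nM with 9000 nM to 50000 nM as the expected range.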

Compound 4, half-maximal inhibitory concentration: 3070 nM
Beside the measured number, compound 4's estimate is 8.1-fold (0.91 log units) above it; measured number outside the range, below it.
By their numbers in this assay, from the lowest: compound 4; then compound 2; then compound 3. At a limit, above all of these: compound 1.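

In this assay, the saturated chain carbon bound to an amide-type nitrogen and a carbonyl carbon responds clearly to substitution, with isopropyl in place of hydrogen giving a 9.8-fold lower number from compound 3 to compound 4 (0.99 log units; beyond the scatter). With this one addition, the carboxy-bearing side chain moves ahead of the side chain of compound 2, showing a 2.2-fold lower number from compound 2 to compound 4 (0.35 log units; beyond the scatter), and there is also an at least 16-fold lower number from compound 1 to compound 4 (1.21 log units; beyond the scatter). That last step rests on a limit and not a number: the limit of > 50000 nM in this assay, at which 1 of the 4 values shown sits.

The compounds shown leave open whether methyl or phenyl at this carbon would do as well as isopropyl. They also leave open whether a methyl ester or primary amide in place of the carboxy group would keep the lower number.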